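Swapping Nitro for Fluoro on the Benzyl Ring

The compounds below may be only part of what the source reports. "The series", "measured", "known", "first", "only" and "open" are said of these compounds alone.

Among the measured compounds shown here, only two compounds have been measured so far, and compound 2 `COc1ccc(CNC(=N)[C@@H]2CCC(=O)N2Cc2ccc([N+](=O)[O-])cc2)cc1` is one of them. In a functional assay on SH-SY5Y cells (Homo sapiens) for cytotoxicity, read by MTT assay, with stated times of 8 h, 30 min and 12 h, tested at 5 uM (on this read-out higher numbers stand for a stronger effect at the one concentration tested and lower numbers for a weaker effect), compound 2 gives 35.2%. Its sole companion, compound 1 `COc1ccc(CNC(=N)[C@@H]2CCC(=O)N2Cc2ccccc2[N+](=O)[O-])cc1`, gives 25.4% in this assay, and the step of a number 9.8 percentage points higher from compound 1 to compound 2 (within the scatter) lies within the scatter, so the two cannot be told apart. Compound 3 `COc1ccc(CNC(=N)[C@@H]2CCC(=O)N2Cc2ccc(F)cc2)cc1` is still to be measured. It differs from compound 2 in one place: fluoro in place of nitro on an aromatic carbon. For the measured compounds named here, no measured step exchanges a nitro group for a fluoro group; the only step available, a number 9.8 percentage points higher from compound 1 to compound 2 (within the scatter), concerns where the nitro group sits, and it was small. With so little to lean on, no step beyond the scatter is expected in this assay. Compound 3 is therefore estimated to give about 30%, within a range from 15% to 45%, which amounts to an expected a number 5.2 percentage points lower from compound 2 to compound 3 (within the scatter).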

Compound 3, a percentage reported as activity, at one concentration (the size of the read-out at that concentration, not a potency): 38.1%
Compound 3: middle estimate off by 8.1 percentage points, on the low side; the range from low to high includes it.
By their numbers in this assay, from the lowest: compounds 1, 2 and 3 (each within the scatter of the next, the first and the last beyond it).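

In this assay, among the compounds shown here, the first exchange of the group itself at this place on the ring, para to a large group, gives a number 2.9 percentage points higher from compound 2 to compound 3 (within the scatter), so a single fluoro stands in for the nitro group, with its 3 heavy atoms, without a readable difference. For the compounds shown here, the comparison of 4-fluorophenyl with 2-nitrophenyl gives a number 12.7 percentage points higher from compound 1 to compound 3 (beyond the scatter), the first step beyond the scatter, though only a modest one. No measurement available here explains either step.

Since this last step changes both the group and where it sits, the compounds shown cannot separate those two contributions. As far as these compounds go, it also remains open how an amine or a carboxylic acid would read at this place on the ring.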